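Cyano in place of chloro on an inactive cytotoxicity pair

The compounds below may be only part of what the source reports. "The series", "measured", "known", "first", "only" and "open" are said of these compounds alone.

Measured compounds:
Compound 1 `O=C(CSc1nnnn1-c1ccccc1)N/N=c1/scc(-c2ccc(Cl)cc2)n1-c1ccccc1`: > 200 ug/mL
Compound 2 `Cn1nnnc1SCC(=O)N/N=c1/scc(-c2ccc(Cl)cc2)n1-c1ccccc1`: "not determined" (no result reported)

In a functional assay on C6 cells (Rattus norvegicus) for cytotoxicity, read by MTT assay, with a stated time of 24 h (on this read-out lower numbers stand for stronger inhibition and higher numbers for weaker inhibition), compound 1 gives > 200 ug/mL, which is a limit of the assay rather than a number. In this assay compound 2 gives "not determined" (no result reported), so it offers no comparison. Compound 1 therefore stands at the limit of > 200 ug/mL in this assay, at which 1 of the 2 values shown sits.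

Compound 3 `N#Cc1ccc(-c2cs/c(=N/NC(=O)CSc3nnnn3-c3ccccc3)n2-c2ccccc2)cc1` differs from compound 1 by cyano in place of chloro on an aromatic carbon. Within the data shown here, no measured pair of this kind exists here, so no change beyond the usual scatter is expected in this assay. Compound 3 is estimated at 250 ug/mL, between 80 ug/mL and 700 ug/mL. The expected step that the limit leaves unreadable from compound 1 to compound 3 is thus within the scatter.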

Compound 3, half-maximal inhibitory concentration: > 200 ug/mL
Compound 3: no number, only a limit (the forecaster's own chance of this, stated with the estimate: 70%); the middle value lies beyond the limit too.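

Among these compounds, compound 1 and compound 3 each give only a limit of the assay, not a number, so no step between them can be read. The compounds shown leave open whether cyano in place of chloro changes the result in this assay at all.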